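Amide-to-benzylamine switch at the ring nitrogen of compound 2

This account rests on a few compounds, and the source may have more. Where it says the series, first, only, none or still open, it means among the compounds named here.

Three compounds of the series have numbers in a functional assay on HEK293 cells for agonist activity at Bile acid receptor (Homo sapiens), read by a luciferase reporter; a lower number here means that less compound is needed, a higher number that more compound is needed for the effect. Compound 2 `CC(C)c1onc(-c2c(Cl)cccc2Cl)c1COc1ccc(N(C)C(=O)c2cccc(C(=O)O)c2)c(C(F)(F)F)n1` gives 537 nM, the lowest of the three. Compound 3 `Cc1cc(OCc2c(-c3c(Cl)cccc3Cl)noc2C(C)C)ncc1[N+](=O)[O-]` gives 1140 nM and compound 1 `Cc1nc(OCc2c(-c3c(Cl)cccc3Cl)noc2C(C)C)ccc1N(C)C(=O)c1ccc(C(=O)O)cc1` gives 1190 nM; both of these lie beyond the scatter above compound 2, so compound 2 stands alone at the low end of what has been measured.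

Compound 4 `CC(C)c1onc(-c2c(Cl)cccc2Cl)c1COc1ccc(N(C)Cc2ccc(OCCO)cc2)c(C(F)(F)F)n1` has not yet been measured. It differs from compound 2 in one place: 4-(2-hydroxyethoxy)benzyl in place of (3-carboxyphenyl)carbonyl on a nitrogen on an aromatic ring. Within the data shown here, no pair already measured isolates this kind of change, so there is no step to lean on. The expectation is that compound 4 lands a little above compound 2 in this assay, with the step from compound 2 to compound 4 estimated at a 2.8-fold higher number from compound 2 to compound 4 (0.45 log units; beyond the scatter), possibly only just beyond the scatter and in the weaker direction. For compound 4 the estimate in this assay is 1500 nM, with a range from 400 nM to 6000 nM.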

Compound 4, half-maximal effective concentration: 155 nM
Compound 4: the middle estimate sits 9.7-fold (0.99 log units) above what was measured, and the stated range ends above it.
By their numbers in this assay, from the lowest: compound 4; then compound 2; then compounds 3 and 1 (each within the scatter of the next).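

In this assay, the nitrogen on an aromatic ring accepts 4-(2-hydroxyethoxy)benzyl in place of (3-carboxyphenyl)carbonyl, with a 3.5-fold lower number from compound 2 to compound 4 (0.54 log units; beyond the scatter), so neither the carboxylic acid nor the carbonyl of compound 2 is needed for activity in this series. The two groups match in heavy-atom, hydrogen-bond donor and hydrogen-bond acceptor counts, so those counts do not distinguish them, and the gain must lie in some other difference between the groups. No measurement available here bears on the reason for this step.

This one step changes the carbonyl link, the acid and the hydroxyethoxy chain together, so the contribution of each stays unresolved. As far as these compounds go, it also remains open whether a benzyl carrying a primary amine or a longer hydroxyalkoxy chain would match compound 4 at 155 nM.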